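Replacing 2-phenylethenyl with 4-(dimethylamino)phenyl in compound 4

The compounds below may be only part of what the source reports. "The series", "measured", "known", "first", "only" and "open" are said of these compounds alone.

Measured in a functional assay on the whole organism (strain Wistar) for inhibition, with Rattus norvegicus as the target, read by paw edema, with stated times of 30 min and 5 h, at a dose of 20 mg/kg by the oral route; a higher number here means more inhibition at the dose given (going by the name of the read-out), a lower number less inhibition:
compound 1 `COc1cc(C)c(Cl)cc1C1=NN(c2ccc(S(N)(=O)=O)cc2)C(c2ccccc2)C1` gives 59.5%
compound 2 `COc1cc(C)c(Cl)cc1C1=NN(c2ccc(S(N)(=O)=O)cc2)C(c2cccc(O)c2)C1` gives 16.7%
compound 3 `COc1cc(C)c(Cl)cc1C1=NN(c2ccc(S(N)(=O)=O)cc2)C(/C=C/c2ccccc2)C1` gives 52.4%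

Compound 3 stands second highest of the three. Its nearest neighbour is compound 1, with a number 7.1 percentage points lower from compound 1 to compound 3 (within the scatter), so the two cannot be told apart. Its furthest is compound 2, with a number 35.7 percentage points higher from compound 2 to compound 3 (beyond the scatter).

Compound 4 `COc1cc(C)c(Cl)cc1C1=NN(c2ccc(S(N)(=O)=O)cc2)C(c2ccc(N(C)C)cc2)C1` differs from compound 3 in one place: 4-(dimethylamino)phenyl in place of 2-phenylethenyl on a saturated ring carbon. Going by the values given here, two measured steps bear on this. The step of a number 7.1 percentage points lower from compound 1 to compound 3 (within the scatter) shows that trading a phenyl for a 2-phenylethenyl at this saturated ring carbon changed little, so a return to a phenyl-type group by itself should change little. The step of a number 42.8 percentage points lower from compound 1 to compound 2 (beyond the scatter), however, shows that adding a hydroxy to that phenyl lowered the number sharply. The 4-(dimethylamino)phenyl also carries a substituent on the phenyl, though a different one, so some downward step is expected in this assay, of uncertain size. For compound 4 the estimate is 40%, between 15% and 65%, meaning an expected step of a number 12.4 percentage points lower from compound 3 to compound 4 (beyond the scatter).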

Compound 4, a percentage reported as inhibition, in the whole organism at one dose (the size of the read-out at that dose, not a potency): 95.2%
Compound 4: middle estimate off by 55.2 percentage points, on the low side; the measured number lies above the stated range.
By their numbers in this assay, from the lowest: compound 2; then compounds 3 and 1 (each within the scatter of the next); then compound 4.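

In this assay, a substituent on the phenyl at this saturated ring carbon need not lower the number: dimethylamino in place of hydrogen gives a number 35.7 percentage points higher from compound 1 to compound 4 (beyond the scatter) and is a large rise, and the exchange of 2-phenylethenyl for 4-(dimethylamino)phenyl gives a number 42.8 percentage points higher from compound 3 to compound 4 (beyond the scatter) of the same kind. Set against the 3-hydroxyphenyl, the 4-(dimethylamino)phenyl gives a number 78.5 percentage points higher from compound 2 to compound 4 (beyond the scatter), so these two substituted phenyls mark the two ends of this small set, and the identity of what the phenyl carries counts for far more than compound 1 and compound 3 alone suggested. No available evidence accounts for this rise.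

Still open, from the compounds shown here alone, is whether a plain amino group or a methoxy on the phenyl would do the same as dimethylamino. Also open, going by these compounds, is how a 3-(dimethylamino)phenyl or a 4-hydroxyphenyl would compare, which would separate the effect of the group from that of its place on the ring.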